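The compounds below may be only part of what the source reports. "The series", "measured", "known", "first", "only" and "open" are said of these compounds alone.

Two compounds of a shared core have been run in a functional assay on SK-BR-3 cells (Homo sapiens) for inhibition, read by CellTiter-Glo, with a stated time of 72 h; a higher number here means a weaker inhibitor, a lower number a stronger inhibitor. Compound 1, `CNc1cc(-n2nc(C(C)C)c3c(-n4cnc(-c5cnn(C)c5)c4)ccnc32)ccc1C(N)=O`, carries a methylamino group beside the carboxamide together with a larger heteroaromatic substituent on the core, and in this assay compound 1 gives 773 nM. Compound 2, `CC(C)c1nn(-c2ccc(C(N)=O)c(N[C@H]3CC[C@H](O)CC3)c2)c2nccc(-c3ccccc3)c12`, replaces those features with a hydroxycyclohexylamino group and a plain phenyl on the core. For compound 2 this assay reports only a limit, > 10000 nM, so compound 2 stands at the limit of > 10000 nM in this assay, at which 1 of the 2 values shown sits, and no number is known for it.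

Compound 3, `CC(C)c1nn(-c2ccc(C(N)=O)c(N[C@H]3CC[C@H](O)CC3)c2)c2nccc(-c3ccoc3)c12`, keeps everything in compound 2 except one substituent on the core: furan-3-yl in place of phenyl on an aromatic carbon.

Going by the values given here, no step between two measured compounds is available to size this change. The only anchor is the limit of compound 2, and a smaller five-membered ring with a single hetero atom is not expected to move the potency by more than the scatter in this assay; the most likely outcome is that compound 3 again returns a limit rather than a number. The step from compound 2 to compound 3 is estimated as a step that the limit leaves unreadable from compound 2 to compound 3. For compound 3 the expected value in this assay is 12000 nM, within a range of 3000 nM to 50000 nM.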

Compound 3, half-maximal inhibitory concentration: > 10000 nM
Compound 3 gave a limit, no number; the forecaster's own chance of this, stated with the estimate: 60%; the middle value is on the limit's open side.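

In this assay compound 3 returns a limit and no number, as compound 2 does: the limit of > 10000 nM in this assay, at which 2 of the 3 values shown sit. Going by these compounds alone, no step can therefore be read between compound 2 and compound 3. The compounds shown leave open how far furan-3-yl and phenyl differ in their effect on potency, as neither compound has a number in this assay.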